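The compounds below may be only part of what the source reports. "The series", "measured", "known", "first", "only" and "open" are said of these compounds alone.

Three compounds have been measured in a functional assay on Ehrlich cells (Mus musculus) for antiproliferative activity, read by trypan blue exclusion, with a stated time of 2 h, tested at 50 ug/mL; on this read-out lower numbers stand for a weaker effect and higher numbers for a stronger effect at the one concentration tested:

compound 1, `N#CC1=C(N)N(c2ccc(S(N)(=O)=O)cc2)C2=C(C(=O)CCC2)C1c1ccc(O)cc1`, gives 100%
compound 2, `N#CC1=C(N)N(c2ccc(S(N)(=O)=O)cc2)C2=C(C(=O)CCC2)C1/C=C/c1ccccc1`, gives 40%
compound 3, `COc1ccc(C2C(C#N)=C(N)N(c3ccc(S(N)(=O)=O)cc3)C3=C2C(=O)CCC3)cc1`, gives 90%

Compound 3 stands second highest of these three numbers. Its nearest neighbour is compound 1, with a number 10 percentage points lower from compound 1 to compound 3 (within the scatter), so these two cannot be told apart. Its furthest neighbour is compound 2, with a number 50 percentage points higher from compound 2 to compound 3 (beyond the scatter).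

Compound 4, `COc1cc(CC2C(C#N)=C(N)N(c3ccc(S(N)(=O)=O)cc3)C3=C2C(=O)CCC3)ccc1O`, is reached from compound 3 by the change (4-hydroxy-3-methoxybenzyl in place of 4-methoxyphenyl on a saturated ring carbon). Two kinds of measured step bear on this. Swapping hydrogen for methyl on the aromatic oxygen gave a number 10 percentage points lower from compound 1 to compound 3 (within the scatter), a small step. Swapping the whole aryl group for 2-phenylethenyl gave a number 60 percentage points lower from compound 1 to compound 2 (beyond the scatter) and a number 50 percentage points higher from compound 2 to compound 3 (beyond the scatter), large steps. Going by the values given here, compound 4 keeps an aromatic ring carrying both oxygens but sets it one carbon further from the saturated ring carbon, a change no measured pair shows. A modest lowering is therefore expected, with wide uncertainty, as a number 15 percentage points lower from compound 3 to compound 4 (beyond the scatter).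

Compound 4 is estimated at 75%, in the range 40% to 100%.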

Compound 4, a percentage reported as activity, at one concentration (the size of the read-out at that concentration, not a potency): 90%
Beside the measured number, compound 4's estimate is 15 percentage points below it; the measured number falls inside the stated range.
By their numbers in this assay, from the lowest: compound 2; then compounds 3, 4 and 1 (each within the scatter of the next).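

In this assay, the longer 4-hydroxy-3-methoxybenzyl group on the saturated ring carbon shows no loss against the directly attached rings, with no change at the digits printed from compound 3 to compound 4 (within the scatter) and a number 10 percentage points lower from compound 1 to compound 4 (within the scatter). This position therefore accepts an aromatic ring set one carbon further out, while the 2-phenylethenyl group of compound 2 stays apart from all the others, with a number 50 percentage points higher from compound 2 to compound 4 (beyond the scatter). No measurement here explains why these groups read as they do.

On these data alone, compound 4 alters the link and the ring's oxygens in a single step, so how a plain benzyl group or a longer chain such as 2-phenylethyl would read at this carbon stays open. With only one concentration shown, whether compounds 1, 3 and 4 would differ in the size of their effect at other concentrations also stays open.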